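The compounds below may be only part of what the source reports. "The series", "measured", "known", "first", "only" and "open" are said of these compounds alone.

In a functional assay on HL-60 cells (Homo sapiens) for cytotoxicity, read by MTT assay, with a stated time of 72 h (a higher number here means a weaker inhibitor, a lower number a stronger inhibitor), compound 1 `O=C(Nc1nnc(-c2ccc(O)c(O)c2)s1)c1ccc(Cl)cc1` gives 14700 nM and compound 2 `CC(=O)Nc1nnc(-c2ccc(O)c(O)c2)s1` gives 42500 nM. Compound 2 therefore has the higher of the two numbers and is the weaker inhibitor of the pair. The next structure, compound 3 `O=C(Nc1nnc(-c2ccc(O)c(O)c2)s1)c1ccccc1`, carries this change from compound 2: phenyl in place of methyl on a carbonyl carbon. In short, it has phenyl in place of methyl on a carbonyl carbon. Within the data shown here, one measured step bears on this change: a 2.9-fold higher number from compound 1 to compound 2 (0.46 log units; beyond the scatter). That modest step put methyl in place of 4-chlorophenyl at the same carbonyl carbon. Phenyl differs from 4-chlorophenyl only by the chlorine, and no measured step tests that chlorine alone. A lower number than for compound 2 is therefore expected, with the size of the shift estimated as a 2.1-fold lower number from compound 2 to compound 3 (0.33 log units; beyond the scatter). The expected value for compound 3 is 20000 nM, with an estimated range from 11000 nM to 36000 nM.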

Compound 3, half-maximal inhibitory concentration: 17600 nM
Estimate against measurement, compound 3: 1.1-fold (0.06 log units) above; low and high end bracket the measured number.
By their numbers in this assay, from the lowest: compounds 1 and 3 (each within the scatter of the next); then compound 2.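

In this assay, compound 3 separates two things that the first step had changed together. Phenyl in place of methyl on the carbonyl carbon gives a 2.4-fold lower number from compound 2 to compound 3 (0.38 log units; beyond the scatter), so the step beyond the scatter appears even without the chlorine, while hydrogen in place of chloro on an aromatic carbon gives a 1.2-fold higher number from compound 1 to compound 3 (0.08 log units; within the scatter), leaving those two compounds indistinguishable in this assay. Nothing measured here explains either step.

Still open, on these data alone, is whether another group in place of that chlorine, such as a methoxy group or an amine, would stand apart from hydrogen and chloro. Also open, as far as these compounds go, is whether a non-aromatic group on the carbonyl carbon, such as cyclohexyl or a longer chain, would match phenyl or stay closer to methyl.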